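Swapping the ketone substituent in a pyrrolinone series

A few compounds are considered here, and "the series" means these few. Any claim that something is new, unique, unknown or untested is made for them only; others in the source may bear on it.

Measured so far:
compound 1, `COc1ccccc1C1C(C(=O)C(C)(C)C)=C(O)C(=O)N1c1ccc(-c2ccon2)cc1`, with 1.3 mL/min/kg in an ADME assay on the whole organism (Rattus norvegicus) for pharmacokinetics; a lower number here means slower removal, a higher number faster removal of the compound
compound 2, `COc1ccc(C(=O)C2=C(O)C(=O)N(c3ccc(-c4ccon4)cc3)C2c2ccccc2OCCO)cc1`, with 67.6 mL/min/kg in this assay

Compound 2 shows the highest clearance of the two numbers in hand, and compound 1 gives a much lower number; the two structures differ in more than one place, so these values are noted side by side without drawing a step from them.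

Compound 3, `CC(C)(C)C(=O)C1=C(O)C(=O)N(c2ccc(-c3ccon3)cc2)C1c1ccccc1OCCO`, has not yet been measured. It differs from compound 2 in one spot: tert-butyl in place of 4-methoxyphenyl on a carbonyl carbon. The rest of the shared core, including the hydroxyethoxy-bearing phenyl ring and the isoxazolyl-phenyl on the ring nitrogen, stays as it is.

Going by the values given here, no measured pair isolates this change, so the expectation rests loosely on the fact that the only compound carrying a tert-butyl ketone, compound 1, sits at the low end with 1.3 mL/min/kg. A step downward in clearance of the size a 4.5-fold lower number from compound 2 to compound 3 (0.65 log units; beyond the scatter) is therefore expected, though with wide uncertainty. For compound 3 the estimate in this assay is 15 mL/min/kg, within a range from 4 mL/min/kg to 50 mL/min/kg.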

Compound 3, clearance: 2.9 mL/min/kg
Beside the measured number, compound 3's estimate is 5.2-fold (0.71 log units) above it; measured number outside the range, below it.
By their numbers in this assay, from the lowest: compound 1; then compound 3; then compound 2.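

In this assay, the group on the carbonyl carbon turns out to carry a very large effect: with the rest of the shared core unchanged, tert-butyl in place of 4-methoxyphenyl gives a 23-fold lower number from compound 2 to compound 3 (1.37 log units; beyond the scatter). Going by these compounds alone, this is the first direct view of that change, since the two earlier compounds differ in more than one place and could not isolate it. The other single change, hydroxymethyl in place of hydrogen on a saturated chain carbon bound to an oxygen on an aromatic ring, gives only a 2.2-fold higher number from compound 1 to compound 3 (0.35 log units; beyond the scatter), so with the tert-butyl ketone in place, clearance moves much less for this change than for the ketone swap. Nothing in the data at hand explains why either number moves as it does.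

With only two groups shown on this carbonyl carbon, it stays open whether low clearance is special to tert-butyl or would also appear with a smaller isopropyl or cyclopropyl group, or with a plain phenyl ring lacking the methoxy. Going by these compounds, it is equally open how clearance would respond if the hydroxyethoxy group gave way to a longer chain or to a chain carrying an amine.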